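Swapping 4-(trifluoromethyl)phenyl for 3-methoxyphenyl on a carbonyl carbon

This account rests on a few compounds, and the source may have more. Where it says the series, first, only, none or still open, it means among the compounds named here.

- compound 1 `COc1cc2oc(-c3cccc(NC(=O)c4ccccc4)c3)cc(=O)c2c(OC)c1OC` gives 11700 nM
- compound 2 `COc1cc2oc(-c3cccc(NC(=O)c4cccc(Br)c4)c3)cc(=O)c2c(OC)c1OC` gives 10900 nM
- compound 3 `COc1cc2oc(-c3cccc(NC(=O)c4ccc(C(F)(F)F)cc4)c3)cc(=O)c2c(OC)c1OC` gives 61100 nM

In a functional assay on HepG2 cells (Homo sapiens) for inhibition, read by MTT assay (a higher number here means a weaker inhibitor of growth, a lower number a stronger inhibitor of growth), compound 3 has the highest number of the three, at 61100 nM. Compound 4 `COc1cccc(C(=O)Nc2cccc(-c3cc(=O)c4c(OC)c(OC)c(OC)cc4o3)c2)c1` differs from it by 3-methoxyphenyl in place of 4-(trifluoromethyl)phenyl on a carbonyl carbon. Two modest measured steps bear on this change, a 5.2-fold higher number from compound 1 to compound 3 (0.72 log units; beyond the scatter) and a 5.6-fold higher number from compound 2 to compound 3 (0.75 log units; beyond the scatter), while a 1.1-fold lower number from compound 1 to compound 2 (0.03 log units; within the scatter). Going by the values given here, no measured compound carries 3-methoxyphenyl, so the expectation is uncertain. A return towards compound 1 and compound 2 is expected. The expected step is a 3.8-fold lower number from compound 3 to compound 4 (0.58 log units; beyond the scatter). Compound 4 is estimated at 16000 nM, with an expected range of 6000 nM to 40000 nM.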

Compound 4, concentration for 50% growth inhibition: 7060 nM
Beside the measured number, compound 4's estimate is 2.3-fold (0.36 log units) above it; the measured number falls inside the stated range.
By their numbers in this assay, from the lowest: compounds 4, 2 and 1 (each within the scatter of the next); then compound 3.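

In this assay, 3-methoxyphenyl on the carbonyl carbon reads like the phenyl of compound 1 and the 3-bromophenyl of compound 2, with a 1.7-fold lower number from compound 1 to compound 4 (0.22 log units; within the scatter) and a 1.5-fold lower number from compound 2 to compound 4 (0.19 log units; within the scatter). Only the 4-(trifluoromethyl)phenyl of compound 3 stands apart among these four, with an 8.7-fold lower number from compound 3 to compound 4 (0.94 log units; beyond the scatter). Nothing measured here accounts for that separation. The compounds shown leave open whether it follows the trifluoromethyl group itself or the place it occupies on the ring. As far as these compounds go, how an amine or a carboxylic acid on that ring would read also remains open.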